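Imidazole substitution pattern on the piperazine-linked arm

This account rests on a few compounds, and the source may have more. Where it says the series, first, only, none or still open, it means among the compounds named here.

Among the compounds with values here, compound 2 `CCCn1cnc(CN2CCN(c3cccc4[nH]c(-c5ccc(C(C)(C)C)cc5)nc34)CC2)c1C` stands lowest of the two numbers measured so far: in an assay on isolated protein for displacement of a labelled ligand from Gonadotropin-releasing hormone receptor (Rattus norvegicus) (on this read-out lower numbers stand for stronger inhibition and higher numbers for weaker inhibition), compound 2 gives 47 nM. Its nearest neighbour, compound 1 `Cn1cnc(CN2CCN(c3cccc4[nH]c(-c5ccc(C(C)(C)C)cc5)nc34)CC2)c1`, gives 98 nM in this assay. Within the data shown here, the only measured step, a 2.1-fold lower number from compound 1 to compound 2 (0.32 log units; beyond the scatter), shows that shifting the substituents on the imidazole ring moved the read-out modestly and beyond the scatter.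

Compound 3 `CCn1cc(CN2CCN(c3cccc4[nH]c(-c5ccc(C(C)(C)C)cc5)nc34)CC2)nc1C` has not yet been measured in this assay. It carries 1-ethyl-2-methyl-1H-imidazol-4-yl in place of 5-methyl-1-propyl-1H-imidazol-4-yl on a saturated chain carbon bound to an amine nitrogen in a ring. The measured step bears on this change only loosely, since it exchanged one imidazole substitution pattern for another without reaching the pattern of compound 3. Given that the two known patterns sit close together, a step from compound 2 to compound 3 of a 1.5-fold higher number from compound 2 to compound 3 (0.17 log units; within the scatter) is expected, with no clear direction beyond the scatter. Compound 3 is therefore estimated at 70 nM in this assay, with a range of 25 nM to 200 nM.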

Compound 3, half-maximal inhibitory concentration: 51 nM
Compound 3: the middle estimate sits 1.4-fold (0.14 log units) above what was measured, and the stated range covers the measured number.
By their numbers in this assay, from the lowest: compounds 2, 3 and 1 (each within the scatter of the next, the first and the last beyond it).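

In this assay, 1-ethyl-2-methyl-1H-imidazol-4-yl on a saturated chain carbon bound to an amine nitrogen in a ring reads level with 5-methyl-1-propyl-1H-imidazol-4-yl (a 1.1-fold higher number from compound 2 to compound 3 (0.04 log units; within the scatter)), so a third imidazole substitution pattern is accommodated here with no difference beyond the scatter. Against 1-methyl-1H-imidazol-4-yl, the new group also stays within the scatter (a 1.9-fold lower number from compound 1 to compound 3 (0.28 log units; within the scatter)), whereas only the step to compound 2 lies beyond it, so the separation from compound 1 is small and not firmly shared by compound 3. No available evidence accounts for these patterns reading alike.

Still open, on these data alone, is whether a longer chain such as butyl in place of the propyl would separate from compound 2 beyond the scatter. The same applies to an amine or a carboxylic acid carried on that chain.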